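One more carbon between the core and the hydroxamate

This account rests on a few compounds, and the source may have more. Where it says the series, first, only, none or still open, it means among the compounds named here.

compound 1 `CN(O)C(=O)CCCCCC(c1c[nH]c2ccccc12)c1c[nH]c2ccccc12`: > 20000 nM
compound 2 `O=C(CCC(c1c[nH]c2ccccc12)c1c[nH]c2ccccc12)NO`: > 20000 nM

In a functional assay on HCT-116 cells (Homo sapiens) for cytotoxicity, read by sulforhodamine B assay, with a stated time of 24 h (on this read-out lower numbers stand for stronger inhibition and higher numbers for weaker inhibition), compound 1 gives > 20000 nM, which is a limit of the assay, not a number. Compound 2 gives > 20000 nM in this assay, again a limit. The step that the two limits leave unreadable from compound 1 to compound 2 is therefore unreadable, as the limit of > 20000 nM in this assay, at which 2 of the 2 values shown sit, shows. Compound 2 thus stands only at a limit among the values shown. Compound 3 `O=C(CCCC(c1c[nH]c2ccccc12)c1c[nH]c2ccccc12)NO` differs from compound 2 by (hydroxycarbamoyl)methyl in place of hydroxycarbamoyl on a saturated chain carbon, three bonds along the chain from two aromatic carbons. For the measured compounds named here, no measured step has a readable size that bears on this change, since both values rest on (the limit of > 20000 nM in this assay, at which 2 of the 2 values shown sit). Compound 3 is expected to stay at the limit, estimated at 25000 nM (range 10000 nM to 60000 nM). The expected step that the limit leaves unreadable from compound 2 to compound 3 is accordingly none beyond the scatter.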

Compound 3, half-maximal inhibitory concentration: > 20000 nM
Compound 3: no number, only a limit (the forecaster's own chance of this, stated with the estimate: 80%); the middle value is on the limit's open side.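

Compound 3 gives > 20000 nM, a limit and not a number, so its steps from compound 1 and compound 2 cannot be read: the limit of > 20000 nM in this assay, at which 3 of the 3 values shown sit.

As far as these compounds go, whether chain length changes cytotoxicity at all across compound 2 and compound 3 stays open.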